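Urea-to-amide step on the shared core, ahead of measurement

The source may hold more compounds than are shown below. What is called first, only, known or untested is meant among the compounds shown, and "the series" means these compounds.

Among the compounds with values here, compound 1 `COc1cc(Cl)cc(-c2nn(-c3cccc(NC(=O)Nc4ccc(Cl)c(C(F)(F)F)c4)c3)cc2-c2ccncc2)c1` and compound 2 `COc1cc(Cl)cc(-c2nn(-c3cccc(NC(=O)Nc4cccc(C(F)(F)F)c4)c3)cc2-c2ccncc2)c1` are the two measured members. Within the data shown here, in a functional assay on UO-31 cells (Homo sapiens) for inhibition, read by sulforhodamine B assay, with a stated time of 48 h, tested at 1 uM (a lower number here means a stronger effect, a higher number a weaker effect of the compound at the concentration tested), compound 1 gives 64% and compound 2 gives 51%; compound 2 thus holds the lowest of the two numbers, the only step known being a number 13 percentage points lower from compound 1 to compound 2 (beyond the scatter), hydrogen in place of chloro on an aromatic carbon.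

Compound 3 `COc1cc(Cl)cc(-c2nn(-c3cccc(NC(=O)c4cccc(C(F)(F)F)c4)c3)cc2-c2ccncc2)c1` follows from compound 2 by 3-(trifluoromethyl)phenyl in place of (3-(trifluoromethyl)phenyl)amino on a carbonyl carbon. Among the measured compounds shown here, no measured step touches the carbonyl carbon or the amide-type nitrogen, so the one known step gives no guide to the size or direction of this change. Without a bearing step, no shift beyond the scatter is assumed, and the range is kept wide.

For compound 3 the expected value in this assay is 60%, estimated within 38% to 88%, which is expected to mean a step of a number 9 percentage points higher from compound 2 to compound 3 (within the scatter).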

Compound 3, a percentage reported as activity, at one concentration (the size of the read-out at that concentration, not a potency): 54%
The estimate for compound 3 lay 6 percentage points above the measured number, and the stated range covers the measured number.
By their numbers in this assay, from the lowest: compounds 2, 3 and 1 (each within the scatter of the next, the first and the last beyond it).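

In this assay, replacing (3-(trifluoromethyl)phenyl)amino with 3-(trifluoromethyl)phenyl on the carbonyl carbon gives a number 3 percentage points higher from compound 2 to compound 3 (within the scatter) and so removes the hydrogen-bond donor counted in the leaving group without a step beyond the scatter, which the hydrogen-for-chloro step alone could not show. The wider replacement of (4-chloro-3-(trifluoromethyl)phenyl)amino by 3-(trifluoromethyl)phenyl on the same carbon gives a number 10 percentage points lower from compound 1 to compound 3 (within the scatter) and also stays within the scatter at this single concentration. No evidence on the cause of either result is at hand.

Going by these compounds, whether a 4-chloro group on the 3-(trifluoromethyl)phenyl ring of the amide would repeat the step seen in the urea pair remains open. Also open, on these data alone, is how a sulfonamide link or a morpholine in place of this aryl group would read in this assay on the shared core.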